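A few compounds are considered here, and "the series" means these few. Any claim that something is new, unique, unknown or untested is made for them only; others in the source may bear on it.

The measured compounds and their values:
Compound 1 `CCCCSc1nc(N)nc2c1ncn2/C=C1/CC1(CO)CO`: > 20000 nM, a limit of the assay
Compound 2 `Nc1nc(NC2CCCCC2)c2ncn(/C=C3/CC3(CO)CO)c2n1`: > 24000 nM, a limit of the assay
Compound 3 `Nc1nc(NC2CC2)c2ncn(/C=C3/CC3(CO)CO)c2n1`: > 20000 nM, a limit of the assay

In an ADME assay on Akata cells (Homo sapiens) for cytotoxicity, with a stated time of 7 days (on this read-out lower numbers stand for higher toxicity in this test and higher numbers for lower toxicity in this test), compound 3 gives > 20000 nM, which is a limit of the assay and not a number. Compound 3 therefore stands only at a limit, and the two other values shown are limits as well: two of the three sit at the limit of > 20000 nM in this assay, at which 2 of the 3 values shown sit, and one at the limit of > 24000 nM in this assay, at which 1 of the 3 values shown sits. The steps that lead to compound 3 are a step that the two limits leave unreadable from compound 1 to compound 3 and a step that the two limits leave unreadable from compound 2 to compound 3, and neither of them can be read, since both ends are limits.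

Compound 4 `CC(C)CSc1nc(N)nc2c1ncn2/C=C1/CC1(CO)CO` carries the following change from compound 3: isobutylsulfanyl in place of cyclopropylamino on an aromatic carbon. The step that bears most closely on it is a step that the two limits leave unreadable from compound 1 to compound 3, where a butylsulfanyl and a cyclopropylamino group stood against each other; its size could not be read, and a step that the two limits leave unreadable from compound 1 to compound 2 was likewise unreadable. Within the data shown here, no measured step shows a readable change in this assay, so no step beyond the scatter is expected here, and compound 4 is expected to sit at a limit again, with a step that the limit leaves unreadable from compound 3 to compound 4 as the estimated step. The estimated value for compound 4 in this assay is 30000 nM, with a range from 15000 nM to 100000 nM.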

Compound 4, half-maximal cytotoxic concentration: > 20000 nM
Compound 4 was reported as a limit; the forecaster's own chance of this, stated with the estimate: 85%; the middle value is on the limit's open side.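

In this assay compound 4 gives > 20000 nM, which is a limit of the assay and not a number. Its steps from compound 1, compound 2 and compound 3 cannot be read. The compounds shown leave open whether exchanging the butylsulfanyl, isobutylsulfanyl, cyclopropylamino and cyclohexylamino groups changes this read-out at all.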